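Terminal aryl change: chloro to trifluoromethyl

The compounds below may be only part of what the source reports. "The series", "measured", "known", "first", "only" and "open" are said of these compounds alone.

Measured in a functional assay on SW-620 cells (Homo sapiens) for inhibition, read by sulforhodamine B assay, with a stated time of 48 h; on this read-out lower numbers stand for stronger inhibition of growth and higher numbers for weaker inhibition of growth:
compound 1 `COc1cc(-c2nn(-c3cccc(NC(=O)Nc4ccc(Cl)c(Cl)c4)c3)cc2-c2ccncc2)ccc1Cl`: 1590 nM
compound 2 `O=C(Nc1cccc(-n2cc(-c3ccncc3)c(-c3ccc(Cl)c(O)c3)n2)c1)Nc1ccc(Cl)c(Cl)c1`: 1460 nM
compound 3 `O=C(Nc1cccc(-n2cc(-c3ccncc3)c(-c3ccc(Cl)c(O)c3)n2)c1)Nc1cc(C(F)(F)F)cc(C(F)(F)F)c1`: 1300 nM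

Compound 2 stands second highest of the three numbers, within the scatter of both compound 1 and compound 3. Compound 4 `O=C(Nc1cccc(-n2cc(-c3ccncc3)c(-c3ccc(Cl)c(O)c3)n2)c1)Nc1ccc(Cl)c(C(F)(F)F)c1` is obtained from compound 2 by trifluoromethyl in place of chloro on an aromatic carbon. For the measured compounds named here, the one measured step, a 1.1-fold lower number from compound 1 to compound 2 (0.04 log units; within the scatter), concerns a different part of the molecule and does not bear on this change. Compound 3 differs from compound 2 only at the same terminal ring, and its value against that of compound 2 shows no difference beyond the scatter. No step beyond the scatter is therefore expected in this assay . For compound 4 the expected value is 1400 nM (700 nM to 2800 nM), meaning an expected 1.0-fold lower number from compound 2 to compound 4 (0.02 log units; within the scatter).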

Compound 4, concentration for 50% growth inhibition: 1150 nM
Compound 4: the middle estimate sits 1.2-fold (0.09 log units) above what was measured; the measured number falls inside the stated range.
By their numbers in this assay, from the lowest: compounds 4, 3, 2 and 1 (each within the scatter of the next).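

At the terminal ring, the only single-group change shown is 3,4-dichlorophenyl to 4-chloro-3-(trifluoromethyl)phenyl, and in this assay it gives a 1.3-fold lower number from compound 2 to compound 4 (0.10 log units; within the scatter). This position, ortho to a chloro group, therefore accepts trifluoromethyl, with four heavy atoms in place of one, without a step beyond the scatter. No measurement at hand accounts for this result.

Still open, from the compounds shown here alone, is whether any group here moves the number beyond the scatter, for example an amine or a carboxylic acid. The effect of changing the remaining chloro group is also unknown.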